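Phenyl in place of cyclopropyl: stability outlook for compound 4

The source may hold more compounds than are shown below. What is called first, only, known or untested is meant among the compounds shown, and "the series" means these compounds.

The series shares one core. Compound 1 `C[C@H](Nc1nc(N)nc(N)c1C#N)c1cc(=O)n2cc(F)ccc2c1-c1ccccc1` has no result in an ADME assay on microsomes from liver (Homo sapiens), read by LC-MS, using NADPH, with a stated time of 30 min, tested at 1 uM; a higher number here means that more of the compound is left, a lower number that less of the compound is left; in this assay compound 1 stands as "not determined" (no result reported). Compound 2 `C[C@H](Nc1ncnc(N)c1C#N)c1c(C2CC2)c(=O)n2cc(F)ccc2c1-c1ccc(F)cc1` gives 93% in this assay, and compound 3 `C[C@H](Nc1nc(N)nc(N)c1C#N)c1c(C2CC2)c(=O)n2cc(F)ccc2c1-c1ccc(F)cc1` gives 86%. Among the compounds with values here, the one step measured, a number 7 percentage points lower from compound 2 to compound 3 (within the scatter), is within the scatter, so compound 2 and compound 3 cannot be told apart on these numbers; compound 3 holds the lower of the two figures, with compound 2 its only neighbour.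

Compound 4 `C[C@H](Nc1nc(N)nc(N)c1C#N)c1c(-c2ccccc2)c(=O)n2cc(F)ccc2c1-c1ccc(F)cc1` differs from compound 3 by phenyl in place of cyclopropyl on an aromatic carbon. Within the data shown here, no measured step concerns a change of this kind: the step from compound 2 to compound 3 bears on a different position and in any case stayed within the scatter, so it gives no direction for this exchange. With both measured numbers high and close, the expectation for compound 4 in this assay is a step of a number 6 percentage points lower from compound 3 to compound 4 (within the scatter), that is, no change beyond the scatter, with a wider range to allow for the unmeasured change. Compound 4 is estimated at 80%, between 55% and 95%.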

Compound 4, percent of the compound remaining: 87%
Beside the measured number, compound 4's estimate is 7 percentage points below it; low and high end bracket the measured number.
By their numbers in this assay, from the lowest: compounds 3, 4 and 2 (each within the scatter of the next).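

In this assay, the exchange of cyclopropyl for phenyl gives a number 1 percentage points higher from compound 3 to compound 4 (within the scatter), the first step read at this position, on an aromatic carbon two atoms from the ring nitrogen. The entering group has 6 heavy atoms against 3 and is aromatic rather than non-aromatic, yet the percent remaining cannot be told apart across this pair, so this read-out accommodates either ring here. No accompanying measurement bears on this result, and no explanation can be offered for it.

Open, on these data alone, is whether an amine, a carboxylic acid or a longer chain at this position would also stay within the scatter of compound 3. Also open, as far as these compounds go, is whether phenyl in place of cyclopropyl reads the same on compound 2, which carries hydrogen where compound 3 carries amino.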